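A few compounds are considered here, and "the series" means these few. Any claim that something is new, unique, unknown or untested is made for them only; others in the source may bear on it.

Measured compounds:
Compound 1 `Cc1cccc(Oc2cccc(CN3CCC(n4cc(C)c(=O)[nH]c4=O)CC3)c2)c1`: > 64000 nM
Compound 2 `Cc1cn(C2CCN(Cc3ccnc(Oc4cccc(Cl)c4)c3)CC2)c(=O)[nH]c1=O`: > 64000 nM

In an ADME assay on MRC5 cells (Homo sapiens) for cytotoxicity, read by fluorescence and resazurin assay, with a stated time of 3 days (on this read-out lower numbers stand for stronger inhibition and higher numbers for weaker inhibition), compound 1 gives > 64000 nM, which is a limit of the assay rather than a number. Compound 2 likewise gives > 64000 nM, again a limit. So compound 1 stands only at the edge of what the assay can report, where (the limit of > 64000 nM in this assay, at which 2 of the 2 values shown sit); nothing finer than that is known about it. Compound 3 `Cc1cn(C2CCN(Cc3cccc(OC4CCCCC4)c3)CC2)c(=O)[nH]c1=O` has not yet been measured. It differs from compound 1 in one place: cyclohexyl in place of 3-methylphenyl on an oxygen on an aromatic ring. Among the compounds with values here, no step between two measured compounds is available here, so no measured change of this kind can be pointed to. The expectation is a step from compound 1 to compound 3 of a step that the limit leaves unreadable from compound 1 to compound 3, that is, none beyond the usual scatter, with the assay most likely reporting a limit once more. Compound 3 is therefore estimated at 100000 nM, within a range from 30000 nM to 300000 nM.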

Compound 3, half-maximal inhibitory concentration: 23600 nM
Compound 3: the middle estimate sits 4.2-fold (0.63 log units) above what was measured, and the stated range ends above it.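

In this assay, within the data shown here, putting cyclohexyl in place of 3-methylphenyl on an oxygen on an aromatic ring gives an at least 2.7-fold lower number from compound 1 to compound 3 (0.43 log units; beyond the scatter), and compound 3 is the only compound here with a read-out that is a number. This shows that the position is not silent: one change here, from an aromatic to a non-aromatic six-membered carbon ring, is enough to shift the read-out towards stronger inhibition. The real size of the step stays unknown, since compound 1 is known only through a limit: the limit of > 64000 nM in this assay, at which 2 of the 3 values shown sit.

The compounds shown do not separate the loss of the aromatic ring from the loss of the methyl group, which a plain phenyl on the same oxygen would help to do. Going by these compounds, it also remains open how this read-out would respond to a smaller group such as methyl, or to an amine on the cyclohexyl ring.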